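The source may hold more compounds than are shown below. What is called first, only, known or untested is meant among the compounds shown, and "the series" means these compounds.

Measured so far in an assay on microsomes from liver for inhibition of 3-hydroxy-3-methylglutaryl-coenzyme A reductase (Rattus norvegicus); a lower number here means a stronger inhibitor, a higher number a weaker inhibitor:
compound 1, `CC(C)c1nc(-c2ccc(F)cc2)c(-c2cc(Cl)cc(Cl)c2)n1/C=C/[C@@H](O)C[C@@H](O)CC(=O)O`, 22 nM
compound 2, `Cc1cc(C)cc(-c2c(-c3ccc(F)cc3)nc(C(C)C)n2/C=C/[C@@H](O)C[C@@H](O)CC(=O)O)c1`, 56 nM

For the measured compounds named here, compound 2 holds the higher of the two numbers in this assay; its only neighbor is compound 1, and the single recorded step between them, a 2.5-fold higher number from compound 1 to compound 2 (0.41 log units; beyond the scatter), came with 3,5-dimethylphenyl in place of 3,5-dichlorophenyl on an aromatic carbon.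

Compound 3, `Cc1cc(F)ccc1-c1c(-c2ccc(F)cc2)nc(C(C)C)n1/C=C/[C@@H](O)C[C@@H](O)CC(=O)O`, has not been measured. It differs from compound 2 in one place: 4-fluoro-2-methylphenyl in place of 3,5-dimethylphenyl on an aromatic carbon. The group that leaves and the group that enters are of equal size by the count above, and neither gains nor loses a donor or acceptor. Going by the values given here, no measured step bears directly on this exchange; the one step known, a 2.5-fold higher number from compound 1 to compound 2 (0.41 log units; beyond the scatter), concerns a different pair of groups at the same aromatic carbon and was modest. On that basis the step from compound 2 to compound 3 in this assay is expected to be small, about a 1.3-fold higher number from compound 2 to compound 3 (0.10 log units; within the scatter), with no clear direction beyond the scatter. Compound 3 is therefore estimated at 70 nM, within a range of 25 nM to 200 nM.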

Compound 3, half-maximal inhibitory concentration: 4 nM
Compound 3: the middle estimate sits 18-fold (1.24 log units) above what was measured; the measured number lies below the stated range.
By their numbers in this assay, from the lowest: compound 3; then compound 1; then compound 2.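

In this assay, the aromatic carbon next to the ring nitrogen proved far more responsive than the first pair of compounds had shown: the exchange of 3,5-dimethylphenyl for 4-fluoro-2-methylphenyl gave a 14-fold lower number from compound 2 to compound 3 (1.15 log units; beyond the scatter), even though the heavy-atom, donor and acceptor counts stayed the same, so these counts do not track the result across this exchange. The entering group also compares favorably with the 3,5-dichlorophenyl group, with a 5.5-fold lower number from compound 1 to compound 3 (0.74 log units; beyond the scatter), so the two groups named as 3,5-disubstituted both give higher numbers than 4-fluoro-2-methylphenyl, and the earlier difference between them is smaller than the gain from either one. For the compounds shown here, nothing available accounts for why this exchange moved the number so far.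

The compounds shown leave the fluorine and the methyl group of 4-fluoro-2-methylphenyl unseparated, so how a 2-methylphenyl or a second 4-fluorophenyl group alone would read at this carbon remains open. Also open, as far as these compounds go, is whether the methyl group could give way to a methoxy group or a chlorine atom while the low number holds.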